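This account rests on a few compounds, and the source may have more. Where it says the series, first, only, none or still open, it means among the compounds named here.

Working notes on the series. Compound 1 `COc1ccc(-c2cc(/C=C/C(=O)c3ccc(N)cc3)[nH]n2)cc1` gives 11600 nM in a functional assay on K562 cells (Homo sapiens) for inhibition, read by sulforhodamine B assay, with a stated time of 48 h; a lower number here means a stronger inhibitor of growth, a higher number a weaker inhibitor of growth. Compound 2 `COc1cc(-c2cc(/C=C/C(=O)c3ccc(N)cc3)[nH]n2)cc(OC)c1OC` gives 23600 nM in this assay, the highest of the two numbers shown; compound 1 stands a step below it, beyond the scatter. Compound 3 `COc1ccc(-c2cc(/C=C/C(=O)c3ccc(N)cc3)[nH]n2)cc1OC` is not yet measured and differs from compound 2 by hydrogen in place of methoxy on an aromatic carbon. Among the measured compounds shown here, no measured pair shows this exact change. Compound 3 carries fewer methoxy groups than compound 2 and more than compound 1, so a modest fall in this assay toward the number of compound 1 is expected, though it may stay within the scatter. Compound 3 is estimated at 16000 nM, range 7000 nM to 36000 nM, an expected step of a 1.5-fold lower number from compound 2 to compound 3 (0.17 log units; within the scatter).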

Compound 3, concentration for total growth inhibition: 36400 nM
Beside the measured number, compound 3's estimate is 2.3-fold (0.36 log units) below it; measured number above the stated range.
By their numbers in this assay, from the lowest: compound 1; then compounds 2 and 3 (each within the scatter of the next).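

With the methoxy group exchanged for hydrogen at this position, this assay gives no separation beyond the scatter (a 1.5-fold higher number from compound 2 to compound 3 (0.19 log units; within the scatter)). Among the compounds shown here, the same methoxy-for-hydrogen exchange in the reverse sense, on the ring of compound 1, does separate (a 3.1-fold higher number from compound 1 to compound 3 (0.50 log units; beyond the scatter)), the first single change to do so, and it goes toward weaker growth inhibition. Nothing at hand gives a reason for either step. Open, going by these compounds, is how a hydroxyl group or a chlorine atom at this position would compare with hydrogen and methoxy. Also open, on these data alone, is whether an amine or a longer alkoxy chain would follow the same direction.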